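Methoxy for Fluoro on a Weakly Inhibiting Sulfonamide Series

The source may hold more compounds than are shown below. What is called first, only, known or untested is meant among the compounds shown, and "the series" means these compounds.

Compound 1, `Cc1ccccc1S(=O)(=O)Nc1ccc(-c2nc3ccccc3o2)cc1`, gives 85000 nM in an assay on cells for inhibition of HSP60/HSP10 (Homo sapiens), with a stated time of 60 min; on this read-out lower numbers stand for stronger inhibition and higher numbers for weaker inhibition.
Compound 2, `O=S(=O)(Nc1ccc(-c2nc3ccccc3o2)cc1)c1cccc(O)c1`, gives 62000 nM in this assay.
Compound 3, `O=S(=O)(Nc1ccc(-c2nc3ccccc3o2)cc1)c1ccccc1F`, gives only a limit of this assay, > 100000 nM, and no number.

Compound 3 therefore stands at the weak end of what can be read, and its position is fixed only by that limit (the limit of > 100000 nM in this assay, at which 1 of the 3 values shown sits). The measured steps that lead to it, an at least 1.1-fold higher number from compound 1 to compound 3 (0.07 log units; that floor lies within the scatter) and an at least 1.6-fold higher number from compound 2 to compound 3 (0.20 log units; that floor lies within the scatter), both lie within the scatter, so none of the three compounds separates from the others in this assay.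

Compound 4, `COc1ccccc1S(=O)(=O)Nc1ccc(-c2nc3ccccc3o2)cc1`, differs from compound 3 by methoxy in place of fluoro on an aromatic carbon. Among the compounds with values here, the step from compound 1 to compound 3 is the one measured change on the same aromatic carbon, and it stayed within the scatter. The expectation is that the step that the limit leaves unreadable from compound 3 to compound 4 also stays within the scatter, with a fair chance that only a limit is reported again. Compound 4 is thus estimated at 110000 nM, within a range from 50000 nM to 250000 nM.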

Compound 4, half-maximal inhibitory concentration: > 100000 nM
Compound 4: no number, only a limit; the forecaster's own chance of this, stated with the estimate: 55%; the middle value does not contradict the limit.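

In this assay compound 4 gives > 100000 nM, which is a limit of the assay and not a number. With limits for both compound 3 and compound 4, the step between them cannot be read, and the two steps that can be read give only floors: an at least 1.6-fold higher number from compound 2 to compound 4 (0.20 log units; that floor lies within the scatter) and an at least 1.1-fold higher number from compound 1 to compound 4 (0.07 log units; that floor lies within the scatter). So methoxy, the larger group with a hydrogen-bond acceptor, gives no measurable number on this aromatic carbon ortho to a large group, any more than fluoro did, and the limit now holds a second compound: the limit of > 100000 nM in this assay, at which 2 of the 4 values shown sit.

As far as these compounds go, whether compound 3 and compound 4 truly differ remains unknown, since neither has a number. Also open, from the compounds shown here alone, is whether an amine or a carboxylic acid in place of the methoxy would give a lower number in this assay.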